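The compounds below may be only part of what the source reports. "The series", "measured", "known", "first", "only" and "open" are said of these compounds alone.

Measured so far: compound 1 `Cc1ccc(S(=O)(=O)NC(=O)Nc2ccccc2C(=O)/C=C/c2cccc(O)c2)cc1`, compound 2 `CCOc1cc(/C=C/C(=O)c2ccccc2NC(=O)NS(=O)(=O)c2ccc(C)cc2)ccc1O`, compound 3 `Cc1ccc(S(=O)(=O)NC(=O)Nc2ccccc2C(=O)/C=C/c2ccc(Cl)cc2)cc1`.

In an ADME assay on the whole organism for cytotoxicity, with Artemia salina as the target, with a stated time of 24 h (on this read-out higher numbers stand for an effect only at larger amounts of compound and lower numbers for an effect already at smaller amounts), compound 1 gives 39.3 ug/mL, compound 2 gives 19.2 ug/mL and compound 3 gives 6.92 ug/mL, the lowest of the three numbers. The steps toward it were a 5.7-fold lower number from compound 1 to compound 3 (0.75 log units; beyond the scatter) and a 2.8-fold lower number from compound 2 to compound 3 (0.44 log units; beyond the scatter), both at the same position as the present change, (1H-pyrrol-2-yl in place of 4-chlorophenyl on a double-bonded chain carbon bound to a double-bonded chain carbon), which leads to compound 4 `Cc1ccc(S(=O)(=O)NC(=O)Nc2ccccc2C(=O)/C=C/c2ccc[nH]2)cc1`. Those two steps, and a 2.0-fold lower number from compound 1 to compound 2 (0.31 log units; beyond the scatter), show that exchanging the ring at this position moves this assay by modest amounts, and that the hydrogen-bond-donor-bearing rings gave the higher numbers. Compound 4 carries such a donor, so a modest rise is expected, a 2.6-fold higher number from compound 3 to compound 4 (0.42 log units; beyond the scatter). Compound 4 is therefore estimated at 18 ug/mL, within a range from 7 ug/mL to 45 ug/mL.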

Compound 4, concentration for half-maximal effect: 32.1 ug/mL
Beside the measured number, compound 4's estimate is 1.8-fold (0.25 log units) below it; the range from low to high includes it.
By their numbers in this assay, from the lowest: compound 3; then compounds 2, 4 and 1 (each within the scatter of the next, the first and the last beyond it).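

In this assay, a five-membered aromatic ring with one hetero atom gives a number set apart from 4-chlorophenyl (a 4.6-fold higher number from compound 3 to compound 4 (0.67 log units; beyond the scatter)) but not from the two hydroxyl-bearing phenyl rings (a 1.7-fold higher number from compound 2 to compound 4 (0.22 log units; within the scatter); a 1.2-fold lower number from compound 1 to compound 4 (0.09 log units; within the scatter)). Across these four compounds, therefore, all three donor-bearing rings stand above 4-chlorophenyl, whatever their ring size, and none goes against this. Nothing given here accounts for the step. The compounds shown leave open whether the donor itself matters, which a 1-methylpyrrol-2-yl or furan-2-yl group could address.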